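Methoxy for Chloro at the Weak End of the Series

The source may report more compounds than this note shows. Statements on the series, on what has been measured and on what is new or still open speak of the compounds shown alone.

Compound 1 `CCn1c(CNc2ccccc2)nnc1SCC(=O)Nc1ccc(Cl)cc1`: > 10000 nM
Compound 2 `CCn1c(CNc2ccccc2)nnc1SCc1nc2cc(F)ccc2o1`: 7800 nM
Compound 3 `CCC(O)c1ccc2oc(CSc3nnc(CNc4ccccc4)n3CC)nc2c1`: 3700 nM

Of the compounds shown here, three sharing one core have been measured in an assay on isolated protein for inhibition of long-chain fatty acid transport protein 1 (Mus musculus); on this read-out lower numbers stand for stronger inhibition and higher numbers for weaker inhibition. Compound 1 gives only the limit (the limit of > 10000 nM in this assay, at which 1 of the 3 values shown sits), so no number is known for it. Among the measured compounds shown here, compound 2 and compound 3 each give a number, and the single step between measured compounds, a 2.1-fold lower number from compound 2 to compound 3 (0.32 log units; beyond the scatter), is a change of one substituent on an aromatic carbon and is modest in size.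

Compound 4 `CCn1c(CNc2ccccc2)nnc1SCC(=O)Nc1ccc(OC)cc1` differs from compound 1 by methoxy in place of chloro on an aromatic carbon. For the measured compounds named here, the one measured step is also a swap of one substituent on an aromatic carbon for another, and it moved the number only modestly; nothing measured here ties methoxy to chloro directly. With compound 1 sitting at the limit, a modest shift in either direction would most likely leave compound 4 at or near that limit too. The expected step that the limit leaves unreadable from compound 1 to compound 4 is therefore small. Compound 4 is estimated at 15000 nM, within a range from 5000 nM to 50000 nM.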

Compound 4, half-maximal inhibitory concentration: > 10000 nM
Compound 4 was reported as a limit; the forecaster's own chance of this, stated with the estimate: 70%; the middle value is on the limit's open side.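

No step can be read from compound 1 to compound 4, because both are reported only as a limit: the limit of > 10000 nM in this assay, at which 2 of the 4 values shown sit. The compounds shown leave open whether methoxy in place of chloro changes the true number for this pair at all, and in which direction.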